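This account rests on a few compounds, and the source may have more. Where it says the series, first, only, none or still open, it means among the compounds named here.

Measured compounds and their values:

Compound 1, `CCn1nc(C)c2c(C)cc(=O)oc21`, in a functional assay on the whole organism with Mus musculus as the target, in the writhing test (on this read-out higher numbers stand for an effect only at larger amounts of compound and lower numbers for an effect already at smaller amounts), gives 24.9 mg/kg.
Compound 2, `CCn1nc2oc(=O)cc(C)c2c1C`, gives 14.6 mg/kg.
Compound 3, `CCOC(=O)Cc1nnc2oc(O)cc(C)c1-2`, gives no number but only a limit, > 100 mg/kg, which is the limit of > 100 mg/kg in this assay, at which 1 of the 3 values shown sits.

Among the two numbers available, the value of compound 2 is the lower one, but its nearest neighbour, compound 1, lies within the usual scatter of this assay, so the two cannot be told apart on these data. Compound 4, `Cc1cc(=O)oc2nn(CCO)c(C)c12`, has not yet been measured. It differs from compound 2 by a single change: hydroxy in place of hydrogen on a saturated chain carbon, two bonds along the chain from an aromatic nitrogen. For the measured compounds named here, no measured pair in this set shows the effect of adding a hydroxy group at such a position, so there is no measured step to lean on. The change is small in the count of atoms, and it sits on the ethyl chain rather than on the shared core, so the expectation is a step of no real size, within the scatter in either direction. For compound 4 the estimated step from compound 2 is a 1.2-fold higher number from compound 2 to compound 4 (0.09 log units; within the scatter), and the estimated value is 18 mg/kg, expected to fall between 7 mg/kg and 50 mg/kg.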

Compound 4, dose for half-maximal effect: > 100 mg/kg
Compound 4 ended at the assay's limit; the forecaster's own chance of this, stated with the estimate: 15%; middle value at least 5.5-fold (0.74 log units) away from the limit.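

In this assay, the change from ethyl to 2-hydroxyethyl gives an at least 6.8-fold higher number from compound 2 to compound 4 (0.83 log units; beyond the scatter), so this saturated chain carbon, two bonds along the chain from an aromatic nitrogen, is not a place where a change passes without effect. The earlier compounds shown here could not show this, since none of them formed a pair differing in one place, and no single change could be read from their values. Here the addition of one hydroxy group to the chain, with the shared core left as it is, is enough to move the read-out beyond the scatter, and the size of that step is only a lower bound, as the value of compound 4 is a limit and not a number: the limit of > 100 mg/kg in this assay, at which 2 of the 4 values shown sit.

The compounds shown leave open whether this step belongs to hydroxy as such or would also appear with another group at the end of the chain, such as a methoxy group, an amine or a carboxylic acid. They also leave open whether a longer chain carrying the hydroxy group would behave in the same way, and whether the same change on the core of compound 1 would give a comparable step.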